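The source may hold more compounds than are shown below. What is called first, only, known or untested is meant among the compounds shown, and "the series" means these compounds.

Compound 1 `O=C(Nc1ccc(Oc2ccnc3[nH]ccc23)cc1)c1ccc(-c2ccc(Cl)cc2)cn1` carries a chloro group on its outer phenyl ring. In a functional assay on A549 cells (Homo sapiens) for cytotoxicity, read by MTT assay, with a stated time of 72 h (on this read-out higher numbers stand for weaker inhibition and lower numbers for stronger inhibition), compound 1 gives > 10000 nM, which is a limit of the assay and not a number. Compound 2 `COc1ccc(-c2ccc(C(=O)Nc3ccc(Oc4ccnc5[nH]ccc45)cc3)nc2)cc1` differs by methoxy in place of chloro on an aromatic carbon; in this assay compound 2 gives > 10000 nM, again a limit. The step that the two limits leave unreadable from compound 1 to compound 2 therefore cannot be sized, because both ends sit at the limit of > 10000 nM in this assay, at which 2 of the 3 values shown sit. For the measured compounds named here, compound 3 `COc1ccc(-c2ccc(C(=O)Nc3ccc(Oc4ccnc5[nH]ccc45)c(F)c3)nc2)cc1` differs from compound 2 by fluoro in place of hydrogen on an aromatic carbon; in this assay compound 3 gives 2240 nM, the only number among the values shown, and the step of an at least 4.4-fold lower number from compound 2 to compound 3 (0.64 log units; beyond the scatter) reads as a real gain. Compound 4 `O=C(Nc1ccc(Oc2ccnc3[nH]ccc23)c(F)c1)c1ccc(-c2ccc(Cl)cc2)cn1` is the next change from compound 3: chloro in place of methoxy on an aromatic carbon. Going by the values given here, the one measured step of the same kind is the reverse one between compound 1 and compound 2, and that one is unreadable. No direction can be taken from it, so the step expected in this assay is none beyond the scatter, a 1.1-fold higher number from compound 3 to compound 4 (0.05 log units; within the scatter). Compound 4 is therefore estimated at 2500 nM, with a range from 800 nM to 10000 nM, and a fair chance that only a limit is returned.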

Compound 4, half-maximal inhibitory concentration: 10000 nM
Estimate against measurement, compound 4: 4.0-fold (0.60 log units) below; low and high end bracket the measured number.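

For the compounds shown here, with the fluoro group present, the change from 4-methoxyphenyl to 4-chlorophenyl can be sized for the first time in this assay: the result is a 4.5-fold higher number from compound 3 to compound 4 (0.65 log units; beyond the scatter). On this core, then, the group at this position does affect the read-out, with methoxy giving the lower number, which the pair without fluoro could not show. The step from compound 1 to compound 2 cannot be read. Fluoro in place of hydrogen in the chloro pair gives only a number no higher from compound 1 to compound 4 (the limit leaves the size open) and no size, so the gain from fluoro is sized only in the methoxy pair, and whether it carries over to the chloro pair stays unresolved: the same change on two cores in this assay, an at least 4.4-fold lower number (0.64 log units; beyond the scatter) from compound 2 to compound 3 and a number no higher (the limit leaves the size open) from compound 1 to compound 4; the limit leaves it open whether they differ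

Going by these compounds, whether methoxy also gives the lower number on the core without fluoro remains open. Also open, on these data alone, is how an amine or a carboxylic acid in place of methoxy on the outer phenyl ring would read in this assay.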